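The source may report more compounds than this note shows. Statements on the series, on what has been measured and on what is new or still open speak of the compounds shown alone.

Three compounds have been measured so far:
compound 1, `CONC(=S)N/N=C1\C(=O)N(CN2CCN(c3ccc(Cl)cc3)CC2)c2ccc(Cl)cc21`, 229000 nM
compound 2, `O=C1/C(=N\NC(=S)NO)c2cc(Cl)ccc2N1CN1CCN(c2ccccc2)CC1`, 273000 nM
compound 3, `O=C1/C(=N\NC(=S)NO)c2cc(F)ccc2N1CN1CCN(c2ccccc2)CC1`, 251000 nM

All three numbers come from an ADME assay on MT4 cells (Homo sapiens) for cytotoxicity, read by spectrophotometry, with a stated time of 5 days; a lower number here means that less compound is tolerated, a higher number that more compound is tolerated. Compound 2 and compound 3 differ in a single place, (fluoro in place of chloro on an aromatic carbon), and the step between them is a 1.1-fold lower number from compound 2 to compound 3 (0.04 log units; within the scatter). Compound 1 and compound 2 are built on different cores, and the difference between the two cores is not broken down here. Compound 1 stands nearest to compound 3 and furthest from compound 2, yet all three numbers sit within the usual scatter of one another, so none of them can be told apart in this assay .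

Compound 4, `CONC(=S)N/N=C1\C(=O)N(CN2CCN(c3ccc(Cl)cc3)CC2)c2ccc(F)cc21`, has not yet been measured. It differs from compound 1 in a single place: fluoro in place of chloro on an aromatic carbon. The description of the place is word for word the same as for the change from compound 2 to compound 3, so this is the same change, carried out on the core of compound 1. Because the earlier step was a 1.1-fold lower number from compound 2 to compound 3 (0.04 log units; within the scatter), the step from compound 1 to compound 4 is expected to be just as small, a 1.1-fold lower number from compound 1 to compound 4 (0.03 log units; within the scatter), and this expectation rests on that one earlier pair alone. Compound 4 is therefore estimated to give 215000 nM in this assay , with a likely range from 120000 nM to 380000 nM.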

Compound 4, half-maximal cytotoxic concentration: 347000 nM
Estimate against measurement, compound 4: 1.6-fold (0.21 log units) below; the measured number falls inside the stated range.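

Replacing chloro with fluoro at this place on the core of compound 1, an aromatic carbon of a six-membered ring of carbon only, gives in this assay a 1.5-fold higher number from compound 1 to compound 4 (0.18 log units; within the scatter), a step too small to separate from repeat-to-repeat variation. Set beside the same change on the other core, the two steps cannot be told apart: the same change on two cores in this assay, a 1.1-fold lower number (0.04 log units; within the scatter) from compound 2 to compound 3 and a 1.5-fold higher number (0.18 log units; within the scatter) from compound 1 to compound 4, 1.6-fold (0.22 log units) apart, within the scatter of two such steps This shows that, across these two pairs, the swap leaves the cytotoxicity number within the scatter on both cores, but it is a weak test of transfer, since neither step is large enough to be read as a real change, and it does not show that the change has exactly the same size on both cores or that it would behave this way on any other core.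

The compounds shown carry only chloro or fluoro at this place, so it remains open how a methyl group, a nitrile or a carboxylic acid there would read in this assay. Also open, from the compounds shown here alone, is whether a step beyond the scatter, if one exists at this place, would carry from one core to the other.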